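The source may report more compounds than this note shows. Statements on the series, on what has been measured and on what is new or still open speak of the compounds shown alone.

Compound 1 `COc1ccc2[nH]c(=O)c(-c3nc4cc(C)c(C)cc4[nH]3)cc2c1` is one of three close relatives built on a shared core. In a functional assay on HepG2 cells (Homo sapiens) for cytotoxicity, read by MTT assay, with a stated time of 48 h (on this read-out lower numbers stand for stronger inhibition and higher numbers for weaker inhibition), compound 1 gives > 100000 nM, and this is a limit of the assay rather than a number. Compound 2 `Cc1ccc2[nH]c(=O)c(-c3nc4ccccc4[nH]3)cc2c1` gives > 100000 nM in this assay, again a limit. Compound 3 `COc1ccc2[nH]c(=O)c(-c3nc4ccccc4[nH]3)cc2c1` gives > 100000 nM, likewise a limit. All three values sit at the limit of > 100000 nM in this assay, at which 3 of the 3 values shown sit, so compound 1 cannot be placed relative to the other two. Within the data shown here, the only measured step between compounds that differ in one place, a step that the two limits leave unreadable from compound 2 to compound 3, is methoxy in place of methyl on an aromatic carbon, and its size cannot be read because both ends are limits. Compound 4 `Cc1ccc2[nH]c(=O)c(-c3nc4cc(C)c(C)cc4[nH]3)cc2c1` differs from compound 1 by methyl in place of methoxy on an aromatic carbon, the reverse of that change. Among the measured compounds shown here, no measured step gives a readable size for this change, so no shift beyond the scatter in this assay is expected, and compound 4 is expected to reach the limit again. This expectation amounts to an estimated step of a number no higher from compound 1 to compound 4 (the limit leaves the size open). Compound 4 is therefore estimated at 100000 nM, with a range from 30000 nM to 300000 nM.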

Compound 4, half-maximal inhibitory concentration: > 100000 nM
Compound 4: a limit, no number; the forecaster's own chance of this, stated with the estimate: 85%; the middle value lies on the limit itself.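

Compound 1 and compound 4 both give only a limit in this assay, so the size of the change from methoxy to methyl cannot be read between them: the limit of > 100000 nM in this assay, at which 4 of the 4 values shown sit. The compounds shown leave open which change to the shared core, if any, would give a real number instead of a limit.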